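The source may hold more compounds than are shown below. What is called first, only, known or untested is meant among the compounds shown, and "the series" means these compounds.

Measured so far in a functional assay on MCF7 cells (Homo sapiens) for inhibition; a higher number here means a weaker inhibitor, a lower number a stronger inhibitor:
- compound 1 `CCCCCC[C@@]1(C)SC(O)=CC1=O`: 16.5 ug/mL
- compound 2 `CCCCCCCC[C@@]1(C)SC(O)=CC1=O`: 12.6 ug/mL
- compound 3 `CCCCCCCC[C@@]1(C)SC(=O)C=C1OC(=O)OC`: 10.7 ug/mL

In this assay, compound 2 gives 12.6 ug/mL, and this value lies within the scatter of those of compound 1 and compound 3. Within the data shown here, the three values therefore set no order among the compounds.

Compound 4 `CCCCCCCC[C@@]1(C)SC(O)=C(C(=O)C(F)(F)F)C1=O` is related to compound 2 by a single change: (trifluoromethyl)carbonyl in place of hydrogen on a double-bonded ring carbon. In words, this is (trifluoromethyl)carbonyl in place of hydrogen on a double-bonded ring carbon.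

Among the measured compounds shown here, the only measured step between two compounds that differ in one place is a 1.3-fold lower number from compound 1 to compound 2 (0.12 log units; within the scatter). It lies in the saturated chain, within the scatter, and says little about the ring carbon that changes here. For the measured compounds named here, no measured compound carries a substituent on that carbon, so the data give no direction for this change. The expectation therefore stays close to compound 2 at 12.6 ug/mL, with wide uncertainty. The estimated step, which is not expected to exceed the scatter, is a 1.3-fold lower number from compound 2 to compound 4 (0.10 log units; within the scatter). For compound 4 the expected value is 10 ug/mL, with an estimated range from 3.5 ug/mL to 28 ug/mL.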

Compound 4, half-maximal inhibitory concentration: 14.7 ug/mL
For compound 4 the middle estimate is 1.5-fold (0.17 log units) below the measured one, and the stated range covers the measured number.
By their numbers in this assay, from the lowest: compounds 3, 2, 4 and 1 (each within the scatter of the next).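

In this assay, the first substituent shown on this double-bonded ring carbon gives a 1.2-fold higher number from compound 2 to compound 4 (0.07 log units; within the scatter), so compound 2 and compound 4 cannot be told apart in this read-out. The earlier compounds shown here all carried hydrogen at this place, and this pair shows that a (trifluoromethyl)carbonyl group of this size can stand on that carbon, next to the ring atom that bears a hydroxy group, without a step beyond the scatter. Nothing available here bears on why this is so.

Going by these compounds, a single group at this place gives no trend, so it remains open whether an acetyl group, a carboxylic acid or an amine on the same carbon would also stay within the scatter of compound 2. On these data alone, it also remains open whether any group at this place can give a step beyond the scatter in either direction.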